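From piperidin-1-yl to pyrrolidin-1-yl in compound 3

The source may report more compounds than this note shows. Statements on the series, on what has been measured and on what is new or still open speak of the compounds shown alone.

Measured in a functional assay on MCF7 cells (Homo sapiens) for antiproliferative activity, read by MTT assay, with a stated time of 24 h; on this read-out lower numbers stand for an effect already at smaller amounts and higher numbers for an effect only at larger amounts of compound:
- compound 1 `CCN(CC)C(=O)CO/N=C(\c1ccc(SC)cc1)c1cccc2ccccc12`: 28000 nM
- compound 2 `CCCCN(C)CCCO/N=C(\c1ccc(SC)cc1)c1cccc2ccccc12`: > 50000 nM, a limit and not a number
- compound 3 `CSc1ccc(/C(=N\OCCCCN2CCCCC2)c2cccc3ccccc23)cc1`: 8000 nM

Compound 3 holds the lower of the two true numbers, with compound 1 as the only other one. Compound 4 `CSc1ccc(/C(=N\OCCCCN2CCCC2)c2cccc3ccccc23)cc1` alters only the ring at the end of the chain: pyrrolidin-1-yl in place of piperidin-1-yl on a saturated chain carbon, four bonds along the chain from an oxygen. Two measured steps reach this end of the molecule: a 3.5-fold lower number from compound 1 to compound 3 (0.54 log units; beyond the scatter) and an at least 6.2-fold lower number from compound 2 to compound 3 (0.79 log units; beyond the scatter). Both exchanged far more than this ring, so they show that the group here matters but not what ring size does. The expected change is a 1.1-fold higher number from compound 3 to compound 4 (0.05 log units; within the scatter), so no step beyond the scatter is expected. Compound 4 is estimated at 9000 nM, with an expected range of 3000 nM to 25000 nM.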

Compound 4, half-maximal effective concentration: > 50000 nM
Compound 4: no number, only a limit; the forecaster's own chance of this, stated with the estimate: 8%; middle value at least 5.5-fold (0.74 log units) from the limit.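

Ring size at the end of the chain matters on its own: with only pyrrolidin-1-yl in place of piperidin-1-yl, this assay gives an at least 6.2-fold higher number from compound 3 to compound 4 (0.79 log units; beyond the scatter). As far as these compounds go, compound 4 has only a limit and not a number, so the full size of that step stays unknown: the limit of > 50000 nM in this assay, at which 2 of the 4 values shown sit. The other readable step, an at least 1.7-fold higher number from compound 1 to compound 4 (0.25 log units; that floor lies within the scatter), exchanges the whole side chain, and the remaining step, with limits on both sides, cannot be read.

From the compounds shown here alone, how azepan-1-yl or morpholin-4-yl would read at the end of this chain stays open, as does whether pyrrolidin-1-yl would fare the same on a shorter chain.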